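Trifluoromethyl on the phenoxy arm of a weak T-type series

The compounds below may be only part of what the source reports. "The series", "measured", "known", "first", "only" and "open" are said of these compounds alone.

Measured so far:
- compound 1, `CN(Cc1ccc(OCCCNC(=N)N)cc1)c1nc2ccc(Oc3ccc(C(F)(F)F)cc3)cc2s1`: 212000 nM
- compound 2, `CN(Cc1ccc(OCCCN)cc1)c1nc2ccc(Oc3ccccc3)cc2s1`: 95000 nM

In an assay on cells for inhibition of Voltage-dependent T-type calcium channel subunit alpha-1H (Homo sapiens), read by FLIPR and calcium flux, with stated times of 600 s and 300 s (a higher number here means a weaker inhibitor, a lower number a stronger inhibitor), compound 2 gives 95000 nM, the lower of the two numbers in hand. Going by the values given here, compound 1 gives 212000 nM in this assay, a weaker result that lies beyond the scatter, though compound 1 and compound 2 differ in more than one place and no single step between them is counted.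

Compound 3, `CN(Cc1ccc(OCCCN)cc1)c1nc2ccc(Oc3ccc(C(F)(F)F)cc3)cc2s1`, keeps the amine chain of compound 2 and changes only the phenoxy ring: trifluoromethyl in place of hydrogen on an aromatic carbon, on an aromatic carbon of a six-membered aromatic ring of carbon only, para to a large group. Among the compounds with values here, no measured pair isolates this change, so the size of the step is an expectation only. Compound 3 is expected to sit somewhat weaker than compound 2, possibly within the scatter, the step of a 1.4-fold higher number from compound 2 to compound 3 (0.14 log units; within the scatter) being the estimate. For compound 3 the estimated value in this assay is 130000 nM, between 60000 nM and 300000 nM.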

Compound 3, half-maximal inhibitory concentration: 248000 nM
The estimate for compound 3 lay 1.9-fold (0.28 log units) below the measured number; the measured number falls inside the stated range.
By their numbers in this assay, from the lowest: compound 2; then compounds 1 and 3 (each within the scatter of the next).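

In this assay, the change from phenoxy to 4-(trifluoromethyl)phenoxy can now be read directly on the amine chain: a 2.6-fold higher number from compound 2 to compound 3 (0.42 log units; beyond the scatter), a modest weakening beyond the scatter. With 4-(trifluoromethyl)phenoxy held constant, placing a hydrogen atom where the group of 3 heavy atoms stood on the amine nitrogen gives a 1.2-fold higher number from compound 1 to compound 3 (0.07 log units; within the scatter), so these two end groups cannot be told apart here. Nothing measured bears on why the trifluoromethyl step arises.

On these data alone, the trifluoromethyl reading rests on a single pair, and whether it holds with the group of 3 heavy atoms on the amine nitrogen remains open. Also open, as far as these compounds go, is how a fluorine, a chlorine or a methoxy group at the same place would compare, and what a longer chain would do.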